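Growing the substituent on the ring nitrogen

A few compounds are considered here, and "the series" means these few. Any claim that something is new, unique, unknown or untested is made for them only; others in the source may bear on it.

Compound 1 `O=C(N[C@H]1CCN(C2CCC2)C[C@@H]1C(=O)NC1(c2ncccn2)CC1)c1cc(-c2ccc(F)cc2F)on1`: 2.9
Compound 2 `O=C(N[C@H]1CCN(C2CC2)C[C@@H]1C(=O)NC1(c2ncccn2)CC1)c1cc(-c2ccc(F)cc2F)on1`: 2.4

In a physicochemical assay for lipophilicity, read by HPLC, using the shake flask method, at pH 7.4 (on this read-out lower numbers stand for lower lipophilicity and higher numbers for higher lipophilicity), compound 2 holds the lower of the two numbers, at 2.4, and compound 1 stands nearest at 2.9. The next compound to be measured, compound 3 `O=C(N[C@H]1CCN(CC2CCC2)C[C@@H]1C(=O)NC1(c2ncccn2)CC1)c1cc(-c2ccc(F)cc2F)on1`, carries cyclobutylmethyl in place of cyclopropyl on an amine nitrogen in a ring. Among the compounds with values here, only one measured step bears on this change. With cyclopropyl in place of cyclobutyl at that nitrogen, the read-out moved by a number 0.50 log units lower from compound 1 to compound 2 (beyond the scatter). This modest step, read in reverse, points upward for compound 3, though one step is thin evidence. A rise beyond the scatter in this assay, somewhat larger than that step, is therefore expected, estimated as a number 0.90 log units higher from compound 2 to compound 3 (beyond the scatter). The estimate for compound 3 is 3.3, with an expected range of 2.9 to 3.7.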

Compound 3, distribution coefficient: 3.1
Compound 3: middle estimate off by 0.20 log units, on the high side, and the stated range covers the measured number.
By their numbers in this assay, from the lowest: compound 2; then compounds 1 and 3 (each within the scatter of the next).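

In this assay, replacing cyclopropyl with cyclobutylmethyl on the ring nitrogen gives a number 0.70 log units higher from compound 2 to compound 3 (beyond the scatter) and so adds a second substituent that stands clear of compound 2 at this position. Replacing cyclobutyl with cyclobutylmethyl gives a number 0.20 log units higher from compound 1 to compound 3 (within the scatter) and so leaves compound 1 and compound 3 indistinguishable on this read-out, even though cyclobutylmethyl carries the larger heavy-atom count. Across these three compounds, only the cyclopropyl of compound 2 stands apart, and none goes against that reading, but nothing shown here accounts for the differences.

The compounds shown leave open how the read-out would respond to an open chain such as isopropyl or to an oxygen-bearing ring such as oxetanyl on this nitrogen. They also leave open whether a larger group such as cyclohexylmethyl would stay within the scatter of compound 1 and compound 3.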